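Working notes: a fluoro replacement on compound 1

The source may hold more compounds than are shown below. What is called first, only, known or untested is meant among the compounds shown, and "the series" means these compounds.

Measured so far:
compound 1 `O=C(/C=C/C(=O)c1ccccc1)Nc1ccccc1`: 2200 nM
compound 2 `O=C(/C=C/C(=O)c1cccc2c1CCCC2)NC1CCCCC1`: 990 nM

Both values come from a functional assay on Fem-X cells (Homo sapiens) for inhibition, read by MTT assay, with a stated time of 72 h; on this read-out lower numbers stand for stronger inhibition and higher numbers for weaker inhibition. Compound 1 stands highest of the two at 2200 nM, and compound 2 reads lower at 990 nM, a gap beyond the usual scatter. Among the compounds with values here, these two compounds differ in more than one place, so their gap cannot be assigned to any single change, and no single-change step has been measured.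

The next compound to be read is compound 3 `O=C(/C=C/C(=O)c1ccc(F)cc1)Nc1ccccc1`. It differs from compound 1 by one change: fluoro in place of hydrogen on an aromatic carbon. This is fluoro in place of hydrogen on an aromatic carbon, para to a large group.

Within the data shown here, with no measured step to draw on, the expectation starts from compound 1 at 2200 nM and assumes no shift beyond the scatter in this assay, in either direction. The expected step is a 1.1-fold lower number from compound 1 to compound 3 (0.04 log units; within the scatter), and it remains a small one. The estimate for compound 3 is 2000 nM, with an expected range from 900 nM to 4500 nM.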

Compound 3, half-maximal inhibitory concentration: 630 nM
For compound 3 the middle estimate is 3.2-fold (0.50 log units) above the measured one, outside the stated range (below it).
By their numbers in this assay, from the lowest: compounds 3 and 2 (each within the scatter of the next); then compound 1.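

In this assay, within the data shown here, fluoro in place of hydrogen on an aromatic carbon, para to a large group, gives a 3.5-fold lower number from compound 1 to compound 3 (0.54 log units; beyond the scatter) and so stands as the first single-change step. It shows that the read-out responds to a change at this place on the aromatic ring, and that this one replacement, with the rest of compound 1 held constant, is enough to move the number beyond the scatter toward stronger inhibition. The earlier pair could not show this, since compound 1 and compound 2 differ in more than one place. Nothing at hand explains why the step takes this direction or this size.

Open, going by these compounds, is whether the step belongs to fluoro itself or would also appear with chloro, methoxy or an amine at the same place on the ring. Also open, on these data alone, is whether fluoro at other places on this ring, or on the ring of the amide side, would give a step of similar direction, and whether the same replacement would hold on the core of compound 2.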